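Methyl on the hydroxy oxygen of compound 2

This account rests on a few compounds, and the source may have more. Where it says the series, first, only, none or still open, it means among the compounds named here.

Two compounds of the series have numbers in an ADME assay on RAW264.7 cells (Mus musculus) for cytotoxicity, read by luminescence and CellTiter-Glo, with a stated time of 18 h, tested at 0.1 uM; a lower number here means a stronger effect, a higher number a weaker effect of the compound at the concentration tested. Compound 1 `C=C1CC[C@H]2C(C)(C)CCC[C@]2(C)[C@H]1C[C@@H](O)C1=CCOC1=O` gives 109% in this assay. Compound 2 `C=C1CC[C@H]2C(C)(C)CCC[C@]2(C)[C@H]1C/C=C1\CC(O)OC1=O` gives 102% in this assay. On the numbers shown, compound 2 stands at one end of the two, and the gap to compound 1 lies within the usual scatter of repeated measurements, so the two compounds cannot be told apart here.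

Compound 3 `C=C1CC[C@H]2C(C)(C)CCC[C@]2(C)[C@H]1C/C=C1\CC(OC)OC1=O` is not yet measured. It differs from compound 2 in one place: methyl in place of hydrogen on an oxygen on a saturated carbon. Within the data shown here, no step between measured compounds of the same kind exists, so nothing measured speaks for a change of size in this assay; the expectation rests on compound 2 alone. The step of no change at the digits printed from compound 2 to compound 3 (within the scatter) is therefore expected to be none beyond the scatter. Compound 3 is expected to give 102% in this assay, with a range from 90% to 114%.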

Compound 3, a percentage reported as activity, at one concentration (the size of the read-out at that concentration, not a potency): 102%
For compound 3 middle estimate and measured number coincide at the digits printed, within the range that was stated.
By their numbers in this assay, from the lowest: compounds 2, 3 and 1 (each within the scatter of the next).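

In this assay, the series now has its first measured step at this position: hydroxy to methoxy, with methyl in place of hydrogen on an oxygen on a saturated carbon, gives no change at the digits printed from compound 2 to compound 3 (within the scatter). The hydrogen on this oxygen can therefore be replaced by methyl without a read-out distinguishable from that of compound 2, although this rests on one pair at one concentration and gives no potency. No measurement bearing on the reason for this result is available.

Still open, going by these compounds, is whether the same holds for a longer chain such as butyl on this oxygen, or for an amine in place of the methoxy group. A single step also leaves open whether compound 2 and compound 3 would remain indistinguishable at higher concentrations.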